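Naphthaldehyde thiosemicarbazones: aryl to benzyl on the thioamide nitrogen

The compounds below may be only part of what the source reports. "The series", "measured", "known", "first", "only" and "open" are said of these compounds alone.

Compound 1 `S=C(N/N=C/c1cccc2ccccc12)Nc1ccccc1` gives 500 nM in a functional assay on B16 cells (Mus musculus), read by spectrophotometry, with a stated time of 3 days; on this read-out higher numbers stand for weaker inhibition and lower numbers for stronger inhibition. Compound 2 `Cc1ccc(NC(=S)N/N=C/c2cccc3ccccc23)cc1` gives 580 nM, and compound 3 `Cc1cccc(NC(=S)N/N=C/c2cccc3ccccc23)c1` gives 450 nM, both in this assay. The three steps among them, a 1.2-fold higher number from compound 1 to compound 2 (0.06 log units; within the scatter), a 1.1-fold lower number from compound 1 to compound 3 (0.05 log units; within the scatter) and a 1.3-fold lower number from compound 2 to compound 3 (0.11 log units; within the scatter), are all within the scatter, so the methyl on an aromatic carbon, wherever it sits, leaves the read-out unchanged. Compound 3 has the lowest of the three numbers, but its distance to compound 1 and to compound 2 stays inside the scatter.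

Compound 4 `S=C(NCc1ccccc1)N/N=C/c1cccc2ccccc12` differs from compound 3 in one place: benzyl in place of 3-methylphenyl on an amide-type nitrogen. Among the measured compounds shown here, no measured step touches this kind of change; the three steps only add or move a methyl on an aromatic carbon, and none alters the group on the amide-type nitrogen itself. The expected step of a 1.3-fold higher number from compound 3 to compound 4 (0.12 log units; within the scatter) therefore rests on a flat series and carries a wide range. In this assay compound 4 is estimated at 600 nM, with a range from 250 nM to 1500 nM.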

Compound 4, half-maximal inhibitory concentration: 270 nM
Estimate against measurement, compound 4: 2.2-fold (0.35 log units) above; low and high end bracket the measured number.
By their numbers in this assay, from the lowest: compounds 4, 3, 1 and 2 (each within the scatter of the next, the first and the last beyond it).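

In this assay, among the compounds shown here, changing the group on the amide-type nitrogen itself gives the only step that passes the scatter: a 2.1-fold lower number from compound 2 to compound 4 (0.33 log units; beyond the scatter), with benzyl in place of 4-methylphenyl, and that step is modest. The other two steps, a 1.7-fold lower number from compound 3 to compound 4 (0.22 log units; within the scatter) and a 1.9-fold lower number from compound 1 to compound 4 (0.27 log units; within the scatter), stay within the scatter, so benzyl stands apart from 4-methylphenyl but not from 3-methylphenyl or phenyl. No measurement at hand bears on this result.

Open, from the compounds shown here alone, is whether a longer chain such as phenethyl, or a ring-free group such as ethyl or an amine-bearing chain, on the amide-type nitrogen would move the number further or leave it within the scatter. Also open, going by these compounds, is whether a methyl on the benzyl ring would leave the read-out as flat as it did on the phenyl ring.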